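This account rests on a few compounds, and the source may have more. Where it says the series, first, only, none or still open, it means among the compounds named here.

Within the data shown here, in a physicochemical assay for lipophilicity (a higher number here means a more lipophilic compound, a lower number a more polar compound), compound 1 `CCOc1ccccc1C1=NC(c2ccccc2)CO1` gives 4.22 and compound 2 `FC(F)(F)c1ccccc1C1=NC(c2ccccc2)CO1` gives 3.71, the lower of the two numbers so far. Compound 3 `Brc1ccccc1C1=NC(c2ccccc2)CO1` has bromo in place of trifluoromethyl on an aromatic carbon. Among the measured compounds shown here, the only measured step is a number 0.51 log units lower from compound 1 to compound 2 (beyond the scatter). For the measured compounds named here, this modest step replaced ethoxy and offers only indirect guidance, as no bromo compound has been measured. No clear move beyond the scatter is therefore expected in this assay. The estimated change is a number 0.04 log units higher from compound 2 to compound 3 (within the scatter). Compound 3 is expected at 3.75, within an estimated range of 3.35 to 4.15.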

Compound 3, partition coefficient: 3.69
For compound 3 the middle estimate is 0.06 log units above the measured one, within the range that was stated.
By their numbers in this assay, from the lowest: compounds 3 and 2 (each within the scatter of the next); then compound 1.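

In this assay, bromo in place of trifluoromethyl on this aromatic carbon, ortho to a large group, gives a number 0.02 log units lower from compound 2 to compound 3 (within the scatter), so 1 heavy atom and 4 heavy atoms here give numbers that cannot be told apart. Bromo in place of ethoxy gives a number 0.53 log units lower from compound 1 to compound 3 (beyond the scatter), which leaves ethoxy as the one group of the three that stands apart. Nothing measured here explains this match.

As far as these compounds go, whether an amine, a carboxylic acid or a longer chain at this place would stay near these numbers remains open. So does whether bromo and trifluoromethyl would also match on another aromatic carbon.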